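Replacing the Methylcarbamoyl Group with Pyridin-3-yl

The source may hold more compounds than are shown below. What is called first, only, known or untested is meant among the compounds shown, and "the series" means these compounds.

Compound 1, `N#Cc1c(N)nc(SCC(N)=O)c(C#N)c1-c1ccc(OCC2CC2)cc1`: 8%
Compound 2, `CNC(=O)CSc1nc(N)c(C#N)c(-c2ccc(OCC3CC3)cc2)c1C#N`: 3%

Of the compounds shown here, two have been measured in an assay on CHO cells for displacement of a labelled ligand from adenosine receptor A3 (Homo sapiens), read by scintillation counting, with a stated time of 120 min, tested at 1 uM; a higher number here means more inhibition at the concentration tested (going by the name of the read-out), a lower number less inhibition. Compound 1 `N#Cc1c(N)nc(SCC(N)=O)c(C#N)c1-c1ccc(OCC2CC2)cc1` gives 8% there. Compound 2 `CNC(=O)CSc1nc(N)c(C#N)c(-c2ccc(OCC3CC3)cc2)c1C#N` gives 3% in this assay; its number and that of compound 1 lie within the scatter of each other, and both show only slight inhibition at the concentration tested. Among the compounds with values here, the single measured step, a number 5 percentage points lower from compound 1 to compound 2 (within the scatter), concerns methyl in place of hydrogen on an amide-type nitrogen, which sits in the group that now leaves.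

Compound 3 `N#Cc1c(N)nc(SCc2cccnc2)c(C#N)c1-c1ccc(OCC2CC2)cc1` differs from compound 2 by pyridin-3-yl in place of methylcarbamoyl on a saturated chain carbon bound to a sulfur. Within the data shown here, that measured step altered only the outer end of the methylcarbamoyl group, whereas the new change removes it altogether; no measured step covers such a replacement. Because a number 5 percentage points lower from compound 1 to compound 2 (within the scatter) stayed within the scatter, the expectation in this assay is no step beyond the scatter. Compound 3 is therefore expected to give about 10%, within a range from 0% to 35%. Compound 3 would then show an expected step of a number 7 percentage points higher from compound 2 to compound 3 (within the scatter).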

Compound 3, a percentage reported as inhibition, at one concentration (the size of the read-out at that concentration, not a potency): 19%
The estimate for compound 3 lay 9 percentage points below the measured number, within the range that was stated.
By their numbers in this assay, from the lowest: compounds 2 and 1 (each within the scatter of the next); then compound 3.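

Whereas methyl on the amide nitrogen left the number within the scatter, pyridin-3-yl on a saturated chain carbon bound to a sulfur gives in this assay both a number 16 percentage points higher from compound 2 to compound 3 (beyond the scatter) and a number 11 percentage points higher from compound 1 to compound 3 (beyond the scatter). The amide group is therefore not required at this place for the inhibition seen, and compound 3 stands highest of the three, although the read-out gives the size of inhibition at one concentration and not a potency. No measurement at hand explains the rise.

The compounds shown leave open whether the ring nitrogen of pyridin-3-yl matters, which phenyl, pyridin-2-yl or pyridin-4-yl at the same place would test. From the compounds shown here alone, it also remains open whether a carboxylic acid, an amine or a longer chain there would raise the number further or lower it.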